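The source may report more compounds than this note shows. Statements on the series, on what has been measured and on what is new or still open speak of the compounds shown alone.

Measured so far:
compound 1 `Cc1n[nH]c2ccc(-c3nc4cnc(N5CCN(C)CC5)cn4c3Nc3cccc(F)c3)cc12` gives 5.41% in a functional assay on CWR22R cells (Homo sapiens) for inhibition, with a stated time of 120 h, tested at 10 uM; a higher number here means more inhibition at the concentration tested (going by the name of the read-out), a lower number less inhibition
compound 2 `COc1ccc(Nc2c(-c3ccc4[nH]nc(C)c4c3)nc3cnc(N4CCN(C)CC4)cn23)cc1` gives 0% in this assay

Compound 1 has the higher of the two numbers, but the gap to compound 2 is within the scatter, so the two cannot be ordered. Within the data shown here, the only measured step, a number 5.4 percentage points lower from compound 1 to compound 2 (within the scatter), changes the group on a nitrogen on an aromatic ring and leaves the read-out essentially where it was.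

Compound 3 `Cc1n[nH]c2ccc(-c3nc4cnc(N5CCN(C)CC5)cn4c3Nc3ccc(Cl)cc3Cl)cc12` is not yet measured in this assay. Relative to compound 1 it differs by 2,4-dichlorophenyl in place of 3-fluorophenyl on a nitrogen on an aromatic ring. This is the same place that was varied between compound 1 and compound 2, and that step stayed within the scatter; both measured numbers sit near the bottom of the inhibition scale. No step beyond the scatter is therefore expected for compound 3, giving an estimated a number 0.4 percentage points lower from compound 1 to compound 3 (within the scatter). The expected value for compound 3 is 5%, with a range of -5% to 20%.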

Compound 3, a percentage reported as inhibition, at one concentration (the size of the read-out at that concentration, not a potency): 9.53%
Compound 3: middle estimate off by 4.5 percentage points, on the low side, and the stated range covers the measured number.
By their numbers in this assay, from the lowest: compounds 2, 1 and 3 (each within the scatter of the next).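

At this position, on a nitrogen on an aromatic ring, 2,4-dichlorophenyl in place of 3-fluorophenyl gives a number 4.1 percentage points higher from compound 1 to compound 3 (within the scatter) in this assay, and 2,4-dichlorophenyl in place of 4-methoxyphenyl gives a number 9.5 percentage points higher from compound 2 to compound 3 (within the scatter). Among these compounds, the earlier pair covered only two rings, each with a single substituent; a ring with two chlorines now also leaves the read-out within the scatter. No measurement at hand explains this flat result.

As far as these compounds go, all three groups here are substituted phenyl rings, so it remains open whether a cyclohexyl ring, a short alkyl chain or a phenyl ring bearing a carboxylic acid would give a step beyond the scatter. From the compounds shown here alone, the rest of the shared core is the same in all three compounds, so the effect of changes there also remains open.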